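The source may hold more compounds than are shown below. What is called first, only, known or untested is meant among the compounds shown, and "the series" means these compounds.

Three compounds give a starting picture in an ADME assay on HEK293 cells (Homo sapiens) for cytotoxicity, read by MTT assay; on this read-out lower numbers stand for higher toxicity in this test and higher numbers for lower toxicity in this test. Compound 1 `c1ccc(C(O[C@H]2CCN(c3ccccc3)[C@@H](c3ccccc3)C2)c2ccccc2)cc1` gives 77.8 ug/mL. Compound 2 `c1ccc(C(O[C@H]2CCN(c3ccccc3)[C@H](c3ccccc3)C2)c2ccccc2)cc1` gives 112 ug/mL. Compound 3 `CN1CCC(OC(c2ccc(Cl)cc2)c2ccc(Cl)cc2)CC1` gives 25.5 ug/mL, the lowest of the three numbers: compound 1 stands nearest and compound 2 furthest, both of them beyond the scatter from compound 3. Among the measured compounds shown here, the only measured step, a 1.4-fold higher number from compound 1 to compound 2 (0.16 log units; within the scatter), rests on nothing more than a change of configuration at one ring carbon (the fact that compounds 1 and 2 differ only in the configuration as drawn), and it does not move the number beyond the scatter.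

Compound 4 `CC(C)[C@H]1C[C@@H](OC(c2ccc(Cl)cc2)c2ccc(Cl)cc2)CCN1C` is not yet measured. It differs from compound 3 in one place: isopropyl in place of hydrogen on a saturated ring carbon, an isopropyl in place of hydrogen on a saturated ring carbon. For the measured compounds named here, no measured step here adds a carbon group to a ring carbon, so the one step from compound 1 to compound 2 gives only a weak guide: a single change of this kind left the number within the scatter. On that basis the expected step, a 1.0-fold lower number from compound 3 to compound 4 (0.01 log units; within the scatter), is small and of no settled direction. Compound 4 is therefore estimated at 25 ug/mL, between 10 ug/mL and 60 ug/mL.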

Compound 4, concentration lethal to 50% of the cells: 17.9 ug/mL
Beside the measured number, compound 4's estimate is 1.4-fold (0.15 log units) above it; measured number inside the range.
By their numbers in this assay, from the lowest: compounds 4 and 3 (each within the scatter of the next); then compounds 1 and 2 (each within the scatter of the next).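

Among the compounds shown here, compound 4 gives the first reading of a carbon group on this saturated ring carbon, next to the ring nitrogen and next to the ring atom that bears a methyl group. In this assay, isopropyl in place of hydrogen here, which adds 3 heavy atoms and no hydrogen-bond donor or acceptor, gives a 1.4-fold lower number from compound 3 to compound 4 (0.15 log units; within the scatter), so the two compounds cannot be told apart in this test and the position accepts this branched group without a clear shift in the read-out. The information available offers no measured property that could explain this outcome, and the one known difference in configuration concerns another pair of compounds.

The compounds shown leave open whether a methyl group, a longer chain, an amine or a carboxylic acid on this same ring carbon would move the number beyond the scatter. They also leave open whether isopropyl drawn in the other configuration at this carbon, or placed on a different ring carbon, would give a number that stands apart from that of compound 3.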